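The source may report more compounds than this note shows. Statements on the series, on what has been measured and on what is new or still open speak of the compounds shown alone.

Measured so far in an ADME assay on L02 cells (Homo sapiens) for cytotoxicity, read by MTT assay, with a stated time of 48 h; a higher number here means a weaker inhibitor, a lower number a stronger inhibitor: compound 1 `CCN1CCN(C[C@H]2CN(c3ccc(-n4cc(-c5ccccn5)cn4)c(F)c3)C(=O)O2)CC1` gives 99 ug/mL. Compound 2 `O=C1O[C@@H](CN2CCCCC2)CN1c1ccc(-n2cc(-c3ccccn3)cn2)c(F)c1` gives only a limit of this assay, > 400 ug/mL. Compound 3 `O=C1CSC(=O)N1C[C@H]1CN(c2ccc(-n3cc(-c4ccccn4)cn3)c(F)c2)C(=O)O1` likewise gives only a limit, > 400 ug/mL.

Compound 2 therefore stands at the limit of > 400 ug/mL in this assay, at which 2 of the 3 values shown sit, a limit and not a number, shared with one other value. Compound 4 `COC[C@H]1CN(c2ccc(-n3cc(-c4ccccn4)cn3)c(F)c2)C(=O)O1` differs from it by methoxy in place of piperidin-1-yl on a saturated chain carbon bound to a saturated ring carbon. Going by the values given here, the steps that bear on this position are an at least 4.0-fold higher number from compound 1 to compound 2 (0.60 log units; beyond the scatter) and an at least 4.0-fold higher number from compound 1 to compound 3 (0.60 log units; beyond the scatter), both reaching the limit; the step that the two limits leave unreadable from compound 2 to compound 3 is unreadable. Two different groups at this position both leave the number at the limit, so no move beyond the scatter is expected, an at least 1.1-fold lower number from compound 2 to compound 4 (0.05 log units; that floor lies within the scatter). Compound 4 is estimated at 350 ug/mL, between 120 ug/mL and 900 ug/mL.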

Compound 4, half-maximal inhibitory concentration: > 400 ug/mL
Compound 4: only a limit was reported; the forecaster's own chance of this, stated with the estimate: 60%; middle value at least 1.1-fold (0.05 log units) from the limit.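

In this assay, methoxy in place of 4-ethylpiperazin-1-yl gives an at least 4.0-fold higher number from compound 1 to compound 4 (0.60 log units; beyond the scatter), so a small group with no ring also reaches the limit, as piperidin-1-yl and 2,4-dioxo-1,3-thiazolidin-3-yl did. Going by these compounds alone, compound 1 remains the only compound with a number, and the steps among compound 2, compound 3 and compound 4 cannot be read. Compound 2 now shares its limit with two other compounds: the limit of > 400 ug/mL in this assay, at which 3 of the 4 values shown sit.

The compounds shown leave open whether piperazin-1-yl without the ethyl, or morpholin-4-yl, would give a readable number at this place.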